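Dropping the Methoxy Group: Expectation for Compound 4

The source may report more compounds than this note shows. Statements on the series, on what has been measured and on what is new or still open speak of the compounds shown alone.

Compound 1 `COC[C@H](NC1CCN(CCCc2c[nH]c3ccc(-n4cnnc4)cc23)CC1)c1ccccc1`: 0.9 nM
Compound 2 `CC(C)=CCN(C)C1CCN(CCCc2c[nH]c3ccc(-n4cnnc4)cc23)CC1`: 1.8 nM
Compound 3 `O[C@@H]1Cc2ccccc2[C@H]1NC1CCN(CCCc2c[nH]c3ccc(-n4cnnc4)cc23)CC1`: 13 nM

Three measured compounds share one core and differ in a single substituent. In an assay on CHO cells for agonist activity at 5-hydroxytryptamine receptor 1D (Homo sapiens), read by GTPgammaS binding (a higher number here means that more compound is needed for the effect, a lower number that less compound is needed), compound 1 gives 0.9 nM, the lowest of the three numbers. The step of a 2.0-fold higher number from compound 1 to compound 2 (0.30 log units; within the scatter) is within the scatter, while a 14-fold higher number from compound 1 to compound 3 (1.16 log units; beyond the scatter) is large, so this substituent can matter a great deal.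

Compound 4 `C[C@H](NC1CCN(CCCc2c[nH]c3ccc(-n4cnnc4)cc23)CC1)c1ccccc1` differs from compound 1 in one place: hydrogen in place of methoxy on a saturated chain carbon, two bonds along the chain from an amine nitrogen and an aromatic carbon. Within the data shown here, no measured step isolates this change. Compound 2 replaces the whole group with methyl(3-methylbut-2-en-1-yl)amino and still stays close to compound 1, and compound 3 exchanges 2-methoxy-1-phenylethyl for 2-hydroxy-2,3-dihydro-1H-inden-1-yl, a far larger rearrangement than losing a methoxy. Since a complete swap of the group in compound 2 moved little, the modest trimming in compound 4 is expected to move little as well, in either direction, roughly a 1.7-fold higher number from compound 1 to compound 4 (0.22 log units; within the scatter). Compound 4 is therefore estimated at 1.5 nM, with a range from 0.5 nM to 5 nM.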

Compound 4, half-maximal effective concentration: 12 nM
The estimate for compound 4 lay 8.0-fold (0.90 log units) below the measured number; the measured number lies above the stated range.
By their numbers in this assay, from the lowest: compounds 1 and 2 (each within the scatter of the next); then compounds 4 and 3 (each within the scatter of the next).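

Taking away the methoxy alone proves to be a large change (a 13-fold higher number from compound 1 to compound 4 (1.12 log units; beyond the scatter)) in this assay, so this single group on the saturated chain carbon counts for much, which no earlier step could isolate. The closeness of compound 2 to compound 1 therefore says little about this position, since the new compound sits well apart from compound 2 (a 6.7-fold higher number from compound 2 to compound 4 (0.82 log units; beyond the scatter)) and cannot be told apart from compound 3 (a 1.1-fold lower number from compound 3 to compound 4 (0.03 log units; within the scatter)), whose substituent differs far more. Nothing measured here gives the reason for this result.

The compounds shown leave open whether the oxygen or simply the extra atoms matter at this carbon. An amine or an ethoxy group in the same place could help separate those two readings.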